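The compounds below may be only part of what the source reports. "The series", "measured", "known", "first", "only" and "open" are said of these compounds alone.

Compound 1 `Cc1ccc(F)cc1NC(=O)Nc1cc(C(C)(C)C)nn1-c1ccccc1`: 4.1 degrees C
Compound 2 `Cc1ccc(NC(=O)Nc2cc(C(C)(C)C)nn2-c2ccccc2)cc1`: 4.7 degrees C

Within the data shown here, in an assay on isolated protein for inhibition of serine/threonine-protein kinase 10 (Homo sapiens), read by thermal shift assay, tested at 10 uM (on this read-out higher numbers stand for stronger stabilisation of the target against heat and lower numbers for weaker stabilisation of the target), compound 2 gives 4.7 degrees C, and compound 1 gives 4.1 degrees C; the two numbers lie within the scatter of each other, the only measured step being a number 0.60 degrees C higher from compound 1 to compound 2 (within the scatter). Compound 3 `CC(C)(C)c1cc(NC(=O)Nc2cc(F)cc(F)c2)n(-c2ccccc2)n1` carries the change (3,5-difluorophenyl in place of 4-methylphenyl on an amide-type nitrogen). Among the measured compounds shown here, the one step at this place, from a fluorine-bearing ring to a methyl-bearing ring, stayed within the scatter, so a shift back to a fluorine-bearing ring is expected to stay within it as well. The expected step is a number 0.40 degrees C lower from compound 2 to compound 3 (within the scatter). Compound 3 is therefore estimated at 4.3 degrees C, between 2.8 degrees C and 5.8 degrees C.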

Compound 3, shift of the target's melting temperature: 2.5 degrees C
Beside the measured number, compound 3's estimate is 1.8 degrees C above it; the measured number lies below the stated range.
By their numbers in this assay, from the lowest: compound 3; then compounds 1 and 2 (each within the scatter of the next).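

In this assay the ring on this amide-type nitrogen proved able to move the number: with 3,5-difluorophenyl there is a number 2.2 degrees C lower from compound 2 to compound 3 (beyond the scatter) and a number 1.6 degrees C lower from compound 1 to compound 3 (beyond the scatter) in the two steps, whereas the earlier step stayed within the scatter. Fluorine as such does not go with the fall, since compound 1 also bears fluorine and stays within the scatter of compound 2; of the three, only compound 3 lacks a methyl on this ring. On these data alone, whether the lost methyl or the added fluorine matters more stays open, as does how a 4-methoxyphenyl or 3-chlorophenyl ring would read here. The data shown offer no evidence on why the number falls.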